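The source may report more compounds than this note shows. Statements on the series, on what has been measured and on what is new or still open speak of the compounds shown alone.

Measured so far in a physicochemical assay for lipophilicity, read by HPLC, at pH 7.5; on this read-out lower numbers stand for lower lipophilicity and higher numbers for higher lipophilicity:

compound 1 `CCOc1ccccc1-c1ccc(-c2nc3cnccc3c(NC(C)C(=O)O)c2C#N)cc1`: 2.1
compound 2 `CC[C@@H](Nc1c(C#N)c(-c2ccc(-c3ccc(OC)cc3)cc2)nc2cnccc12)C(N)=O`: 2.7
compound 3 `CCOc1ccccc1-c1ccc(-c2nc3cnccc3c(N[C@H](CC)C(=O)NS(C)(=O)=O)c2C#N)cc1`: 2.2

Compound 2 at 2.7 stands highest of the three and lies beyond the scatter from both compound 1 and compound 3. The next in line is compound 4 `CC[C@@H](Nc1c(C#N)c(-c2ccc(-c3ccccc3C)cc2)nc2cnccc12)C(N)=O` which has not yet been measured. The change leading to it is 2-methylphenyl in place of 4-methoxyphenyl on an aromatic carbon in short 2-methylphenyl in place of 4-methoxyphenyl on an aromatic carbon, para to a large group.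

Among the measured compounds shown here, only one measured step in this assay isolates a single change. That step, a number 0.10 log units higher from compound 1 to compound 3 (within the scatter) falls on a nitrogen on an aromatic ring, so it gives no direct measure of an exchange on an aromatic carbon. For the measured compounds named here, no measured pair covers the present exchange. The expectation therefore starts from compound 2 at 2.7 and rests on the structural change alone, with an entering group that carries no oxygen. A modest rise is expected, with the estimated step being a number 0.40 log units higher from compound 2 to compound 4 (beyond the scatter) on this read-out. For compound 4 the estimated value is 3.1 with 2.7 to 3.5 as the expected range.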

Compound 4, distribution coefficient: 3
For compound 4 the middle estimate is 0.10 log units above the measured one; measured number inside the range.
By their numbers in this assay, from the lowest: compounds 1 and 3 (each within the scatter of the next); then compounds 2 and 4 (each within the scatter of the next).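

Among the compounds shown here, this is the first measured step at an aromatic carbon, para to a large group, in this assay; the earlier step fell on a nitrogen on an aromatic ring and could say nothing about this place. Exchanging 4-methoxyphenyl for 2-methylphenyl gives a number 0.30 log units higher from compound 2 to compound 4 (within the scatter), so at this position the read-out does not separate the two groups, even though the entering group has no oxygen and no hydrogen-bond acceptor, while the leaving group has one of each. No supporting evidence is available to explain this outcome.

The exchange alters the substituent and its place on the outer ring at once, so this single pair cannot assign the step to either alteration, and it offers no basis for a trend at this position. A plain phenyl, or a phenyl carrying an amine or a carboxylic acid, would test whether this position tolerates wider exchanges with as little movement in the read-out, or whether the closeness of compound 2 and compound 4 holds only for these two groups.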